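Removing a Methyl from the Methoxy of Compound 2

This account rests on a few compounds, and the source may have more. Where it says the series, first, only, none or still open, it means among the compounds named here.

Compound 2 `COc1cc(-c2nn(-c3cccc(NC(=O)Nc4ccc(Cl)c(C(F)(F)F)c4)c3)cc2-c2ccncc2)ccc1Cl` is one of three related compounds measured in a functional assay on HOP-92 cells (Homo sapiens) for inhibition, read by sulforhodamine B assay, with a stated time of 48 h (on this read-out lower numbers stand for stronger inhibition of growth and higher numbers for weaker inhibition of growth), where compound 2 gives 1480 nM. Compound 1 `COc1cc(-c2nn(-c3cccc(NC(=O)Nc4cccc(C(F)(F)F)c4)c3)cc2-c2ccncc2)ccc1Cl` gives 1770 nM; the step of a 1.2-fold lower number from compound 1 to compound 2 (0.08 log units; within the scatter) means the two cannot be told apart on this read-out. Compound 3 `COc1cc(-c2nn(-c3cccc(NC(=O)c4ccccc4)c3)cc2-c2ccncc2)ccc1Cl`, with a plain benzamide in place of the urea, gives 4710 nM, and the step of a 3.2-fold higher number from compound 2 to compound 3 (0.50 log units; beyond the scatter) is beyond the scatter. Compound 2 therefore sits at the low end together with compound 1, with compound 3 clearly higher.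

Compound 4 `O=C(Nc1cccc(-n2cc(-c3ccncc3)c(-c3ccc(Cl)c(O)c3)n2)c1)Nc1ccc(Cl)c(C(F)(F)F)c1` differs from compound 2 in a single place: hydrogen in place of methyl on an oxygen on an aromatic ring. Among the compounds with values here, none of the measured steps involves this oxygen; a 1.2-fold lower number from compound 1 to compound 2 (0.08 log units; within the scatter) and a 2.7-fold higher number from compound 1 to compound 3 (0.43 log units; beyond the scatter) both concern the urea and amide side of the molecule, so the data offer no direct guide to this change. With nothing pointing either way, the step of a 1.1-fold higher number from compound 2 to compound 4 (0.03 log units; within the scatter) is expected to stay within the scatter. Compound 4 is estimated at 1600 nM, with a range from 600 nM to 4500 nM.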

Compound 4, concentration for total growth inhibition: 1460 nM
Compound 4: middle estimate off by 1.1-fold (0.04 log units), on the high side; measured number inside the range.
By their numbers in this assay, from the lowest: compounds 4, 2 and 1 (each within the scatter of the next); then compound 3.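

Before this result, no measured step touched this oxygen: every earlier comparison concerned the urea and amide side of the molecule. Within the data shown here, the first step at this position, from methoxy to hydroxy, gives in this assay (a 1.0-fold lower number from compound 2 to compound 4 (0.01 log units; within the scatter)), so on this read-out the two compounds cannot be told apart, and removing the methyl from this oxygen shows no detectable effect on growth inhibition with the 4-chloro-3-(trifluoromethyl)phenyl urea in place. No supporting measurement is available to explain this outcome.

Going by these compounds, whether a longer chain on this oxygen, such as ethyl, or an amine in place of the hydroxy would also show no difference remains open. Also open, on these data alone, is whether the same swap would give the same result in compound 1 or in the benzamide compound 3.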